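The source may hold more compounds than are shown below. What is called first, only, known or untested is meant among the compounds shown, and "the series" means these compounds.

Measured compounds:
- compound 1 `COc1ccc(S(=O)(=O)Oc2ccccc2/C=C(\C#N)C(=O)Nc2nnc(-c3cccs3)s2)cc1`: 67%
- compound 2 `N#C/C(=C\c1ccccc1OS(=O)(=O)c1ccc([N+](=O)[O-])cc1)C(=O)Nc1nnc(-c2cccs2)s1`: 23%
- compound 3 `Cc1ccc(S(=O)(=O)Oc2cccc(/C=C(\C#N)C(=O)Nc3nnc(-c4ccccc4Cl)s3)c2)cc1`: 67%

All three were tested in a functional assay on HL-60 cells (Homo sapiens) for inhibition, read by CCK-8 assay, with a stated time of 48 h, tested at 20 uM; a lower number here means less inhibition of growth, a higher number more inhibition of growth at the concentration tested. Compound 2 stands lowest of the three numbers: compound 1 lies above it beyond the scatter, and compound 3 lies equally far above it, also beyond the scatter. Among the compounds with values here, the only step between compounds that differ in one place is a number 44 percentage points lower from compound 1 to compound 2 (beyond the scatter), brought about by a nitro in place of a methoxy on an aromatic carbon; that step is large.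

Compound 4 `Cc1ccc(Cc2nnc(NC(=O)/C(C#N)=C/c3ccccc3OS(=O)(=O)c3ccc([N+](=O)[O-])cc3)s2)cc1` has not been measured. It differs from compound 2 by 4-methylbenzyl in place of thiophen-2-yl on an aromatic carbon. Within the data shown here, no measured step touches this position, so the one large step known does not bear on it directly. Compound 1 and compound 3 carry different groups on the shared core and give the same value in this assay, which gives no sign that this part of the molecule moves the number much. Compound 4 is therefore expected to stay near compound 2, with a step of a number 7 percentage points higher from compound 2 to compound 4 (within the scatter) that is expected to lie within the scatter. The estimate for compound 4 is 30%, expected between 10% and 60%.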

Compound 4, percent growth inhibition at one concentration: 17%
The estimate for compound 4 lay 13 percentage points above the measured number; the range from low to high includes it.
By their numbers in this assay, from the lowest: compounds 4 and 2 (each within the scatter of the next); then compounds 1 and 3 (each within the scatter of the next).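

In this assay, putting 4-methylbenzyl in place of thiophen-2-yl on the aromatic carbon next to the ring sulfur gives a number 6 percentage points lower from compound 2 to compound 4 (within the scatter). Within the data shown here, this is the first direct reading at this position: with the nitro group held constant, a five-membered aromatic ring with 1 hetero atom gives way to a group with a six-membered aromatic ring of carbon only, and the number does not move beyond the scatter. Nothing measured here accounts for this outcome.

From the compounds shown here alone, both compounds carry the nitro group and sit low in this assay, so whether the same exchange would be as quiet with methoxy in its place remains open. Going by these compounds, it is also open how a carboxylic acid or an amine on a longer chain would behave at this position.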